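Cyclohexyl to hydroxypentyl on the amide of compound 1

This account rests on a few compounds, and the source may have more. Where it says the series, first, only, none or still open, it means among the compounds named here.

Measured in an assay on HEK293 cells for displacement of a labelled ligand from adenosine receptor A2b (Homo sapiens), read by scintillation counting, with a stated time of 30 min; on this read-out lower numbers stand for stronger inhibition and higher numbers for weaker inhibition:
- compound 1 `COc1cccc2cc(C(=O)NC3CCCCC3)c(=N)oc12` gives 20000 nM
- compound 2 `COC(=O)/C(C#N)=C/c1cccc(OC)c1O` gives 1000 nM

Compound 1 stands at the higher of the two numbers; compound 2 sits lower by a gap beyond the usual scatter. Among the compounds with values here, no measured pair differs in a single place, so no step size is known from the data. Compound 3 `COc1cccc2cc(C(=O)NCCCCCO)c(=N)oc12` differs from compound 1 by 5-hydroxypentyl in place of cyclohexyl on an amide-type nitrogen. Within the data shown here, with no measured step covering this exchange, no change beyond the scatter is expected in this assay; the step is estimated as no change at the digits printed from compound 1 to compound 3 (within the scatter). Compound 3 is expected at 20000 nM, within 7000 nM to 60000 nM.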

Compound 3, inhibition constant: 1260 nM
For compound 3 the middle estimate is 16-fold (1.20 log units) above the measured one, and the stated range ends above it.
By their numbers in this assay, from the lowest: compounds 2 and 3 (each within the scatter of the next); then compound 1.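

The amide nitrogen is a position that responds in this assay: 5-hydroxypentyl in place of cyclohexyl gives a 16-fold lower number from compound 1 to compound 3 (1.20 log units; beyond the scatter), a large step on the shared core. The exchange removes a carbon-only ring and adds a hydrogen-bond donor and acceptor, and this single step cannot separate these differences. Nothing available explains the step.

As far as these compounds go, whether the gain needs the hydroxy group remains open, as a plain pentyl chain would show. An amine or a carboxylic acid in its place, or a longer chain, would test how far this position tolerates change.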